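Aryl Thiosemicarbazones of a Terpenoid Scaffold Against Melanoma Cells

A few compounds are considered here, and "the series" means these few. Any claim that something is new, unique, unknown or untested is made for them only; others in the source may bear on it.

Compound 1 `CC1=CC[C@@H]([C@@](C)(O)CCCC(C)(C)NC(=S)NN)CC1` gives > 100000 nM in a functional assay on UACC-62 cells (Homo sapiens) for cytotoxicity, read by sulforhodamine B assay (a higher number here means a weaker inhibitor of growth, a lower number a stronger inhibitor of growth), a value that is a limit of the assay.
Compound 2 `CC1=CC[C@@H]([C@@](C)(O)CCCC(C)(C)NC(=S)N/N=C\c2ccc(O)cc2)CC1` gives 40100 nM in this assay.
Compound 3 `CC1=CC[C@@H]([C@@](C)(O)CCCC(C)(C)NC(=S)N/N=C\c2ccc(N(C)C)cc2)CC1` gives > 100000 nM in this assay, again a limit of the assay.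

Compound 3 thus stands at the limit, as noted in the limit of > 100000 nM in this assay, at which 2 of the 3 values shown sit, and only compound 2 returns a number. The step of an at least 2.4-fold lower number from compound 1 to compound 2 (0.39 log units; beyond the scatter) brought the series below that limit, and the step of an at least 2.4-fold higher number from compound 2 to compound 3 (0.39 log units; beyond the scatter) took it back up. Compound 4 `CC1=CC[C@@H]([C@@](C)(O)CCCC(C)(C)NC(=S)N/N=C\c2ccccc2Cl)CC1` differs from compound 3 by 2-chlorophenyl in place of 4-(dimethylamino)phenyl on a carbon with a double bond to nitrogen. For the measured compounds named here, neither measured step involves a 2-chlorophenyl group; the two steps show only that the identity of the aryl group decides whether a number or a limit is seen, with compound 2 the sole case of a number. For compound 4 a value near that of compound 2 is therefore expected, 60000 nM, within the range 20000 nM to 150000 nM, with a real chance that only a limit is reported. The expected step is an at least 1.6-fold lower number from compound 3 to compound 4 (0.22 log units; that floor lies within the scatter).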

Compound 4, concentration for total growth inhibition: > 100000 nM
Compound 4: no number, only a limit; the forecaster's own chance of this, stated with the estimate: 45%; middle value at least 1.6-fold (0.22 log units) from the limit.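

In this assay, 2-chlorophenyl in place of 4-hydroxyphenyl on a carbon with a double bond to nitrogen gives an at least 2.4-fold higher number from compound 2 to compound 4 (0.39 log units; beyond the scatter), so compound 2 remains the only aryl compound shown that returns a number. Both ends of the steps from compound 3 to compound 4 and from compound 1 to compound 4 are limits, and those steps cannot be read. With 2-chlorophenyl, as with 4-(dimethylamino)phenyl, the series stays at the limit of the assay: the limit of > 100000 nM in this assay, at which 3 of the 4 values shown sit.

The compounds shown leave open whether a methoxy group or a carboxylic acid in place of hydroxy on an aromatic carbon would return a number. Going by these compounds, how far compound 3 and compound 4 lie beyond the limit also remains unknown.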